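Swapping Bromo for Hydroxy: An Expected Growth Inhibition Value

The compounds below may be only part of what the source reports. "The series", "measured", "known", "first", "only" and "open" are said of these compounds alone.

Three compounds with a shared core have numbers in a functional assay on MCF7 cells (Homo sapiens) for antiproliferative activity; on this read-out higher numbers stand for weaker inhibition of growth and lower numbers for stronger inhibition of growth. Compound 1 `COc1ccc(-c2nc3ccccc3s2)cc1OC` gives 52700 nM. Compound 2 `COc1ccc(-c2nc3cc(F)ccc3s2)cc1Cl` gives 760 nM, and compound 3 `COc1ccc(-c2nc3cc(F)ccc3s2)cc1Br` gives 850 nM. Compound 3 stands second highest of the three numbers: the step of a 1.1-fold higher number from compound 2 to compound 3 (0.05 log units; within the scatter) lies within the usual scatter, while compound 1 sits far higher, beyond it. Compound 4 `COc1ccc(-c2nc3cc(F)ccc3s2)cc1O` differs from compound 3 by hydroxy in place of bromo on an aromatic carbon. Among the measured compounds shown here, the only measured step exchanges one halogen for another and says little about a hydroxy entering; no measured pair shows hydroxy in place of a halogen. Compound 4 is therefore expected to shift by a 3.5-fold higher number from compound 3 to compound 4 (0.55 log units; beyond the scatter) in this assay, with wide uncertainty. Compound 4 is estimated at 3000 nM, within 700 nM to 15000 nM.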

Compound 4, concentration for 50% growth inhibition: 500 nM
For compound 4 the middle estimate is 6.0-fold (0.78 log units) above the measured one; the measured number lies below the stated range.
By their numbers in this assay, from the lowest: compounds 4, 2 and 3 (each within the scatter of the next); then compound 1.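

In this assay, hydroxy in place of bromo gives a 1.7-fold lower number from compound 3 to compound 4 (0.23 log units; within the scatter), and hydroxy in place of chloro gives a 1.5-fold lower number from compound 2 to compound 4 (0.18 log units; within the scatter). At this place, ortho to a methoxy group, a group with one hydrogen-bond donor and one hydrogen-bond acceptor therefore cannot be told apart from either halogen, which have none, so the earlier halogen swap now extends to a non-halogen. Nothing measured here explains this match. Going by these compounds, whether an amine, a carboxylic acid or a longer chain at this place would stay within the same range remains open.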